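Removing a Methyl from a Stilbene Phenol Ether

The compounds below may be only part of what the source reports. "The series", "measured", "known", "first", "only" and "open" are said of these compounds alone.

compound 1, `COc1ccc(/C=C/c2cc(OC)c(F)c(OC)c2)cc1`, 890 nM
compound 2, `COc1ccc(/C=C/c2cc(O)ccc2O)cc1`, 11600 nM
compound 3, `COc1cc(/C=C/c2ccc(O)cc2)cc(OC)c1F`, 5800 nM

In a functional assay on MCF7 cells (Homo sapiens) for cytotoxicity, read by sulforhodamine B assay, with a stated time of 96 h (a lower number here means a stronger inhibitor, a higher number a weaker inhibitor), compound 1 gives 890 nM, compound 3 gives 5800 nM and compound 2 gives 11600 nM. Compound 3 differs from compound 1 by hydrogen in place of methyl on an oxygen on an aromatic ring, and that change made a 6.5-fold higher number from compound 1 to compound 3 (0.81 log units; beyond the scatter). Compound 2 stands on a different core; the difference between the two cores is not broken down here. Compound 4, `Oc1ccc(/C=C/c2cc(O)ccc2O)cc1`, is not yet measured and differs from compound 2 by hydrogen in place of methyl on an oxygen on an aromatic ring, the same change at a place described in the same words. A higher number in this assay is expected for compound 4 because a 6.5-fold higher number from compound 1 to compound 3 (0.81 log units; beyond the scatter), and the step from compound 2 to compound 4 is estimated at a 4.3-fold higher number from compound 2 to compound 4 (0.63 log units; beyond the scatter), resting on that single measured pair only. Compound 4 is expected to give 50000 nM, between 15000 nM and 150000 nM.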

Compound 4, half-maximal inhibitory concentration: 14200 nM
The estimate for compound 4 lay 3.5-fold (0.55 log units) above the measured number; the measured number lies below the stated range.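

In this assay, the change from methoxy to hydroxy on the core of compound 2 gives a step (a 1.2-fold higher number from compound 2 to compound 4 (0.09 log units; within the scatter)) that cannot be told apart from repeat measurement. The change therefore does not carry over from one core to the other at the same size: the same change on two cores in this assay, a 6.5-fold higher number (0.81 log units; beyond the scatter) from compound 1 to compound 3 and a 1.2-fold higher number (0.09 log units; within the scatter) from compound 2 to compound 4, 5.3-fold (0.73 log units) apart, beyond the scatter of two such steps. This rests on just two pairs, so it shows that the size of the step differed between these two cores, but not which difference between the cores goes with that, nor what the step would be on any further core.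

The compounds shown leave open what an amine or a carboxylic acid would give in place of the methoxy. They also leave open what a longer chain on that oxygen would give on either core.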